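Working notes: 2-hydroxyethyl to acetyl on the shared core

A few compounds are considered here, and "the series" means these few. Any claim that something is new, unique, unknown or untested is made for them only; others in the source may bear on it.

- compound 1 `CN1CCN(c2ccc(Nc3ncc4nc(Nc5ccccc5)n(-c5ccccc5)c4n3)cc2)CC1`: 1830 nM
- compound 2 `OCCNc1ccc(Nc2ncc3nc(Nc4ccccc4)n(C4CCCC4)c3n2)cc1`: 2810 nM

Both values come from a functional assay on NCI-H1975 cells (Homo sapiens) for cytotoxicity, read by MTT assay, with a stated time of 72 h; a lower number here means a stronger inhibitor, a higher number a weaker inhibitor. Compound 2 gives 2810 nM, which lies within the scatter of compound 1, so the two cannot be ordered. The next compound to be read is compound 3 `CC(=O)Nc1ccc(Nc2ncc3nc(Nc4ccccc4)n(C4CCCC4)c3n2)cc1`. Its difference from compound 2 is acetyl in place of 2-hydroxyethyl on a nitrogen on an aromatic ring. Within the data shown here, no measured pair shows this change, and the two values in hand say nothing about its direction. In this assay, no step beyond the scatter is expected. The estimated move is a 1.1-fold lower number from compound 2 to compound 3 (0.05 log units; within the scatter). For compound 3 the estimated value is 2500 nM, with an expected range of 900 nM to 7000 nM.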

Compound 3, half-maximal inhibitory concentration: 1210 nM
Beside the measured number, compound 3's estimate is 2.1-fold (0.32 log units) above it; the measured number falls inside the stated range.
By their numbers in this assay, from the lowest: compounds 3, 1 and 2 (each within the scatter of the next, the first and the last beyond it).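

Among these compounds, on a nitrogen on an aromatic ring, with the rest of the shared core unchanged, this assay gives the first reading of a single change: acetyl in place of 2-hydroxyethyl comes with a 2.3-fold lower number from compound 2 to compound 3 (0.37 log units; beyond the scatter), a modest step but one beyond the scatter. The two groups have the same heavy-atom count, so this position responds to a change of group without a change in that count, while the hydrogen-bond donor of 2-hydroxyethyl leaves and a double bond enters. No measured information on the compounds accounts for this step.

On these data alone, whether an amine, a carboxylic acid or a longer acyl chain at this place would move the number further, and in which direction, stays open. So does whether the same change gives a similar step on the core of compound 1.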